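Methoxy addition in an aminothiazole series: cytotoxicity notes

A few compounds are considered here, and "the series" means these few. Any claim that something is new, unique, unknown or untested is made for them only; others in the source may bear on it.

Measured compounds:
Compound 1, `COc1ccc(Nc2nc(-c3ccccn3)cs2)cc1`, gives 140000 nM in an ADME assay on KB cells (Homo sapiens) for cytotoxicity, read by MTT assay, with a stated time of 72 h; on this read-out lower numbers stand for higher toxicity in this test and higher numbers for lower toxicity in this test.
Compound 2, `COc1ccc(Nc2nc(-c3ccccn3)cs2)cc1OC`, gives 62000 nM in this assay.
Compound 3, `Clc1ccc(Nc2nc(-c3ccccn3)c(Cl)s2)nc1`, gives 326000 nM in this assay.

One single-point change is measured: methoxy in place of hydrogen on an aromatic carbon, giving a 2.3-fold lower number from compound 1 to compound 2 (0.35 log units; beyond the scatter). Compound 3 carries a different core; the difference between the core of compound 3 and the core of compound 1 is not broken down here. Compound 3 has the highest of the three numbers, with compound 1 nearest and compound 2 furthest.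

Compound 4, `COc1ccc(-c2nc(Nc3ccc(Cl)cn3)sc2Cl)nc1`, is not yet measured. It differs from compound 3 by methoxy in place of hydrogen on an aromatic carbon. This is the same kind of change as that from compound 1 to compound 2, not the same: there the place was on a six-membered aromatic ring of carbon only, ortho to a methoxy group and meta to a large group, whereas here it is on a six-membered aromatic ring with 1 nitrogen, two atoms from the ring nitrogen, para to a large group.

A step of about a 2.2-fold lower number from compound 3 to compound 4 (0.34 log units; beyond the scatter) is expected for compound 4, resting on a 2.3-fold lower number from compound 1 to compound 2 (0.35 log units; beyond the scatter) and on compound 3 at 326000 nM, with wide uncertainty since the surroundings differ. Compound 4 is estimated at 150000 nM, between 60000 nM and 400000 nM.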

Compound 4, half-maximal cytotoxic concentration: 248000 nM
Beside the measured number, compound 4's estimate is 1.7-fold (0.22 log units) below it; the measured number falls inside the stated range.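

In this assay, methoxy in place of hydrogen on an aromatic carbon gives a 1.3-fold lower number from compound 3 to compound 4 (0.12 log units; within the scatter), a step that cannot be told apart from repeat measurement on this core. Set beside the earlier step, the change gives no sign of acting differently on the two cores: the same change on two cores in this assay, a 2.3-fold lower number (0.35 log units; beyond the scatter) from compound 1 to compound 2 and a 1.3-fold lower number (0.12 log units; within the scatter) from compound 3 to compound 4, 1.7-fold (0.23 log units) apart, within the scatter of two such steps. Within the data shown here, this does not show that the step carries over unchanged: only two pairs are at hand, only one of the two steps stands beyond the scatter, and core and place vary together, with the methoxy entering a six-membered aromatic ring of carbon only in one pair and a six-membered aromatic ring with 1 nitrogen in the other.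

Open, going by these compounds, is whether the small step on the core of compound 3 holds for other groups at the same place, such as an ethoxy, an amine or a carboxylic acid. Also open, on these data alone, is what methoxy does at other places on that ring, which would help to separate the effect of place from that of core.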